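Fluoro to trifluoromethyl beneath a clearance limit

This account rests on a few compounds, and the source may have more. Where it says the series, first, only, none or still open, it means among the compounds named here.

In an ADME assay on microsomes from liver (Mus musculus) for metabolic stability (a lower number here means slower removal, a higher number faster removal of the compound), compound 1 (`O=C(O)Cn1nc(Cc2nc3cc(F)c(OCC4CC4)cc3[nH]2)c2ccccc2c1=O`) gives only a limit, < 53.4 mL/min/kg. Compound 2 (`CC(C)(C(=O)O)c1nn(Cc2cn3cc(OCC4CC4)c(Cl)cc3n2)c2ccccc2c1=O`) also gives only a limit, < 63.4 mL/min/kg. Compound 3 (`CCC(C(=O)O)c1nn(Cc2cn3cc(OCC4CC4)c(Cl)cc3n2)c2ccccc2c1=O`) gives a limit too, < 56.7 mL/min/kg. None of the three has an exact number, so compound 1 cannot be ranked against the other two.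

Compound 4 (`O=C(O)Cn1nc(Cc2nc3cc(C(F)(F)F)c(OCC4CC4)cc3[nH]2)c2ccccc2c1=O`) differs from compound 1 in one place: trifluoromethyl in place of fluoro on an aromatic carbon. Trifluoromethyl replaces fluoro on an aromatic carbon, ortho to a cyclopropylmethoxy group.

Going by the values given here, the only measured step is a step that the two limits leave unreadable from compound 2 to compound 3. Among the compounds with values here, it involves a different group and has no readable size, so no measured step bears directly on this change. With no size to carry over, no step beyond the usual scatter is expected in this assay, and no direction can be favoured. The expected outcome is a step that the limit leaves unreadable from compound 1 to compound 4. The expectation rests on compound 1, whose limit is < 53.4 mL/min/kg. For compound 4 the estimated clearance is 40 mL/min/kg, with an expected range of 20 mL/min/kg to 60 mL/min/kg.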

Compound 4, clearance: < 88.4 mL/min/kg
Compound 4 gave a limit, no number; the forecaster's own chance of this, stated with the estimate: 80%; the middle value lies beyond the limit too.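

In this assay compound 4 gives only a limit, < 88.4 mL/min/kg. Compound 1 also gives only a limit, < 53.4 mL/min/kg, so the step between these two compounds cannot be read. The compounds shown leave open whether trifluoromethyl in place of fluoro on an aromatic carbon changes clearance at all, and in which direction.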